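The source may hold more compounds than are shown below. What is called first, only, known or untested is meant among the compounds shown, and "the series" means these compounds.

Compound 1 `C=C1C=CC(=O)[C@@H]2[C@H](Cc3ccc(OCOC)cc3)CC[C@H]12`: 226 nM
Compound 2 `C=C1C=CC(=O)[C@@H]2[C@H](Cc3ccccc3)CC[C@H]12`: 678 nM

In a functional assay on NCI-H460 cells (Homo sapiens) for antiproliferative activity, with a stated time of 72 h (a higher number here means a weaker inhibitor, a lower number a stronger inhibitor), compound 2 has the higher of the two numbers, at 678 nM, so it is the weaker inhibitor. Compound 3 `C=C1C=CC(=O)[C@@H]2[C@H](Cc3ccc(O)cc3)CC[C@H]12` differs from it by one change: hydroxy in place of hydrogen on an aromatic carbon. Among the measured compounds shown here, only one measured step bears on this: a 3.0-fold higher number from compound 1 to compound 2 (0.48 log units; beyond the scatter), where hydrogen replaces methoxymethoxy on an aromatic carbon. Hydroxy is a different group, so that step is only a rough guide. A modest move towards a lower number is expected, with a 1.9-fold lower number from compound 2 to compound 3 (0.29 log units; within the scatter) as the estimated step. Compound 3 is estimated at 350 nM, within a range of 120 nM to 900 nM.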

Compound 3, half-maximal inhibitory concentration: 77.6 nM
Compound 3: middle estimate off by 4.5-fold (0.65 log units), on the high side; measured number below the stated range.
By their numbers in this assay, from the lowest: compound 3; then compound 1; then compound 2.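

In this assay, hydroxy in place of hydrogen on this aromatic carbon gives an 8.7-fold lower number from compound 2 to compound 3 (0.94 log units; beyond the scatter) and so improves on the unsubstituted ring. Hydrogen in place of methoxymethyl on that oxygen gives a 2.9-fold lower number from compound 1 to compound 3 (0.46 log units; beyond the scatter) and shows that, among these compounds, the free hydroxy outperforms the capped oxygen. No measurement here explains either step. 

The compounds shown leave open whether an amine, a carboxylic acid or a simple methoxy group at this position would match hydroxy. They also leave open whether hydroxy would give the same gain elsewhere on the ring.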